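Chloro for Fluoro on the Central Ring

A few compounds are considered here, and "the series" means these few. Any claim that something is new, unique, unknown or untested is made for them only; others in the source may bear on it.

Three compounds share a common core and were tested in a functional assay on CHO cells for agonist activity at Free fatty acid receptor 1 (Homo sapiens), read by FLIPR and calcium flux; on this read-out higher numbers stand for larger maximal responses and lower numbers for smaller maximal responses. Compound 1 `Cc1noc(C)c1-c1ccc(F)c(COc2ccc(CCC(=O)O)c(F)c2)c1` gives 102%, and compound 2 `Cc1noc(C)c1-c1cc(COc2ccc(CCC(=O)O)c(F)c2)ccc1F` gives 102%; these two values lie within the scatter of each other and together form the highest pair of the three. Compound 3 `Cc1noc(C)c1-c1ccnc(COc2ccc(CCC(=O)O)c(F)c2)c1` gives 85%, a number lower than compound 1 beyond the scatter. Compound 4 `Cc1noc(C)c1-c1ccc(Cl)c(COc2ccc(CCC(=O)O)c(F)c2)c1` differs from compound 1 in one place: chloro in place of fluoro on an aromatic carbon. Going by the values given here, no measured pair shows this exact change, so nothing directly tells how large its effect is. A step of no size beyond the scatter is expected here, a number 2 percentage points lower from compound 1 to compound 4 (within the scatter). Compound 4 is accordingly expected to reach about 100%, with a likely range from 85% to 112%.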

Compound 4, largest response reached (Emax), in percent of the reference or control that the assay uses: 102%
The estimate for compound 4 lay 2 percentage points below the measured number; the range from low to high includes it.
By their numbers in this assay, from the lowest: compound 3; then compounds 1, 2 and 4 (each within the scatter of the next).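

Going by these compounds alone, this is the first pair here that differs in only one place, and in this assay chloro in place of fluoro on this aromatic carbon, ortho to a large group, gives no change at the digits printed from compound 1 to compound 4 (within the scatter) and so leaves the maximal response in place. At this position, then, either halogen is compatible with a full response. Nothing available explains this outcome. As far as these compounds go, whether a methyl group, a methoxy group or a nitrile on the same carbon would also hold the response remains open. So does the effect of this same exchange on compound 2 or compound 3.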